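The source may report more compounds than this note shows. Statements on the series, on what has been measured and on what is new or still open speak of the compounds shown alone.

Measured so far in a functional assay on NCI-H522 cells (Homo sapiens) for cytotoxicity, with a stated time of 3 days; on this read-out lower numbers stand for stronger inhibition and higher numbers for weaker inhibition: compound 1 `C=Cc1nc2ccccc2n1C` gives 2340 nM, and compound 2 `C#Cc1nc(/C=C/C(=O)Nc2ccc(Cl)cc2)cs1` gives 370 nM. Compound 3 `C=Cc1nc2ccccc2s1` gives only a limit, > 40000 nM, in this assay. Among the measured compounds shown here, compound 3 thus stands at the limit of > 40000 nM in this assay, at which 1 of the 3 values shown sits, and is the one member of the set without a number. The next compound, compound 4 `C#Cc1nc2ccccc2s1`, is not yet measured; it differs from compound 3 by ethynyl in place of vinyl on an aromatic carbon. For the measured compounds named here, no measured pair shows this same change on this core, so the size of the step from compound 3 to compound 4 is uncertain; compound 2 carries ethynyl and gives a number, but on a different scaffold. Compound 4 is expected to give about 20000 nM, between 3000 nM and 60000 nM, a step estimated as an at least 2.0-fold lower number from compound 3 to compound 4 (0.30 log units; that floor lies within the scatter).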

Compound 4, half-maximal inhibitory concentration: 860 nM
For compound 4 the middle estimate is 23-fold (1.37 log units) above the measured one; measured number outside the range, below it.
By their numbers in this assay, from the lowest: compound 2; then compound 4; then compound 1. At a limit, above all of these: compound 3.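

In this assay, ethynyl in place of vinyl on an aromatic carbon, next to the ring nitrogen and next to the ring sulfur, gives an at least 46-fold lower number from compound 3 to compound 4 (1.66 log units; beyond the scatter). Among the compounds shown here, this is the first matched reading of the change on one core, since ethynyl had earlier appeared only on the different scaffold of compound 2. Compound 3 remains a limit, so the step has a floor but no upper bound: the limit of > 40000 nM in this assay, at which 1 of the 4 values shown sits.

Going by these compounds, whether an amine, a nitrile or a longer chain at this position would match ethynyl stays open. So does whether the same change lowers the number on the core of compound 1.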